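The source may report more compounds than this note shows. Statements on the series, on what has been measured and on what is new or still open speak of the compounds shown alone.

Compound 1 `COC(C)(C)CCCC(C)C/C=C/C(C)=C/C(=O)OC(C)(C)C` stands highest of the three compounds measured in a physicochemical assay for lipophilicity (a higher number here means a more lipophilic compound, a lower number a more polar compound), where compound 1 gives 6.36. Compound 3 `CCOC(=O)/C=C(C)/C=C/CC(C)CCC=C(C)C` comes nearest to it: in this assay compound 3 gives 6.19, a gap within the scatter. Compound 2 `CCOC(=O)/C=C(C)/C=C/CC(C)CCCC(C)(C)O` lies furthest away, with a value in this assay for compound 2 of 4.65.

The next compound, compound 4 `CCC(=O)/C=C(C)/C=C/CC(C)CCCC(C)(C)OC`, differs from compound 1 in one place (ethyl in place of tert-butoxy on a carbonyl carbon).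

For the measured compounds named here, the only measured step available, a number 1.54 log units higher from compound 2 to compound 3 (beyond the scatter), concerns a different change at a different place, so no measured step bears directly on the swap of tert-butoxy for ethyl on the carbonyl carbon. Going from compound 1 to compound 4, the group that leaves counts five heavy atoms with one hydrogen-bond acceptor, while the group that enters counts two carbon atoms and none; a downward step in this assay beyond the scatter is therefore expected, a number 1.06 log units lower from compound 1 to compound 4 (beyond the scatter). For compound 4 a value of 5.3 is estimated, expected to fall between 4.7 and 5.9.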

Compound 4, partition coefficient: 5.07
Compound 4: middle estimate off by 0.23 log units, on the high side; the range from low to high includes it.
By their numbers in this assay, from the lowest: compound 2; then compound 4; then compounds 3 and 1 (each within the scatter of the next).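

Within this assay, the carbonyl carbon proves to be a position where the group matters: ethyl in place of tert-butoxy turns the tert-butoxycarbonyl of compound 1 into the propanoyl of compound 4 (a number 1.29 log units lower from compound 1 to compound 4 (beyond the scatter)). For the compounds shown here, the earlier step (a number 1.54 log units higher from compound 2 to compound 3 (beyond the scatter)) concerned only the far end of the chain, so this is the first measured change at the carbonyl end, and it too lies beyond the scatter. No measurement here explains why the number moves by this much.

This single swap removes carbon atoms and the hydrogen-bond acceptor together, so the compounds shown cannot say how much of the step belongs to each. A methoxy group, an amide or a carboxylic acid on the same carbonyl carbon would remain to be compared with the tert-butoxy of compound 1.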